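A few compounds are considered here, and "the series" means these few. Any claim that something is new, unique, unknown or untested is made for them only; others in the source may bear on it.

Measured in a physicochemical assay for solubility, at pH 7; on this read-out lower numbers stand for lower solubility and higher numbers for higher solubility:
- compound 1 `CC(=O)N1CCN(C(=O)N2Cc3c(NC(=O)c4ccc(F)cc4)n[nH]c3C2(C)C)CC1`: > 225000 nM (a limit)
- compound 2 `CC(C)(C)C(=O)N1Cc2c(NC(=O)c3cccnc3)n[nH]c2C1(C)C`: 207000 nM
- compound 3 `CN1CCC(C(=O)N2Cc3c(NC(=O)NCc4ccccc4)n[nH]c3C2(C)C)CC1`: > 225000 nM (a limit)

Compound 1 gives only a limit, not a number, and stands at the limit of > 225000 nM in this assay, at which 2 of the 3 values shown sit. The unmeasured compound 4 `CC1(C)c2[nH]nc(NC(=O)c3ccc(F)cc3)c2CN1C(=O)C1CCN(C2CC2)CC1` keeps the core of compound 1 and exchanges one group on a carbonyl carbon: 1-cyclopropylpiperidin-4-yl in place of 4-acetylpiperazin-1-yl on a carbonyl carbon. Within the data shown here, no measured pair shows what such an exchange does, so any forecast rests on these few values. Among the measured compounds shown here, compound 2, the only exact number here, gives 207000 nM, which points to a high reading. A small downward step is expected, estimated as an at least 1.3-fold lower number from compound 1 to compound 4 (0.12 log units; that floor lies within the scatter), and it may stay within the usual scatter. In this assay the expected value for compound 4 is 170000 nM, in an estimated range from 70000 nM to 225000 nM.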

Compound 4, solubility: > 225000 nM
Compound 4 was reported as a limit (the forecaster's own chance of this, stated with the estimate: 40%); at least 1.3-fold (0.12 log units) between middle value and limit.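

Compound 1 and compound 4 are both reported only as limits in this assay, so no step between them can be read: the limit of > 225000 nM in this assay, at which 3 of the 4 values shown sit.

From the compounds shown here alone, what putting 1-cyclopropylpiperidin-4-yl in place of 4-acetylpiperazin-1-yl does to this read-out stays open.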